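The source may report more compounds than this note shows. Statements on the series, on what has been measured and on what is new or still open speak of the compounds shown alone.

Measured compounds in a functional assay on DU-145 cells (Homo sapiens) for inhibition, read by trypan blue exclusion, with a stated time of 96 h; a lower number here means a stronger inhibitor of growth, a higher number a weaker inhibitor of growth:
- compound 1 `CN(C)c1ccc(/C=C(/SCc2ccc(F)cc2)C(=O)c2ccc(Br)cc2)cc1`: 50000 nM
- compound 2 `O=C(/C(=C\c1ccc(O)cc1O)Sc1ccccc1Br)c1ccc(Br)cc1`: 50000 nM
- compound 3 `O=C(/C(=C\c1ccccc1O)Sc1ccccc1Br)c1ccc(Br)cc1`: 50000 nM

Compound 3 stands level with compounds 1 and 2 at the digits shown; the one single-point step, no change at the digits printed from compound 2 to compound 3 (within the scatter), lies within the scatter. Compound 4 `CN(C)c1ccc(/C=C(/Sc2ccccc2Br)C(=O)c2ccc(Br)cc2)cc1` differs from compound 3 by 4-(dimethylamino)phenyl in place of 2-hydroxyphenyl on a double-bonded chain carbon bound to a double-bonded chain carbon. Within the data shown here, no measured step mirrors this exchange; the nearest bearing is that compound 1, which already carries the 4-(dimethylamino)phenyl group, gives 50000 nM, the same figure as compound 3. The expectation is therefore no step beyond the scatter, no change at the digits printed from compound 3 to compound 4 (within the scatter), and compound 4 is estimated at 50000 nM, in a range from 25000 nM to 100000 nM.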

Compound 4, concentration for 50% growth inhibition: > 100000 nM
Compound 4 gave a limit, no number (the forecaster's own chance of this, stated with the estimate: 40%); middle value at least 2.0-fold (0.30 log units) away from the limit.
By their numbers in this assay, from the lowest: compounds 1, 2 and 3 (each within the scatter of the next). At a limit, above all of these: compound 4.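

In this assay compound 4 is read only as a limit, not a number: the limit of > 100000 nM in this assay, at which 1 of the 4 values shown sits.

On a double-bonded chain carbon bound to a double-bonded chain carbon, the entering 4-(dimethylamino)phenyl gives an at least 2.0-fold higher number from compound 3 to compound 4 (0.30 log units; that floor lies within the scatter) and an at least 2.0-fold higher number from compound 2 to compound 4 (0.30 log units; that floor lies within the scatter), while 2-bromophenyl in place of 4-fluorobenzyl on a sulfur gives an at least 2.0-fold higher number from compound 1 to compound 4 (0.30 log units; that floor lies within the scatter). Each floor lies within the scatter, so no step is shown to exceed it, but none of these exchanges lowers the number.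

Open, as far as these compounds go, is whether a carboxylic acid or a morpholine in this place would give a number below the shared figure of compounds 1, 2 and 3.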